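The source may hold more compounds than are shown below. What is called first, only, known or untested is meant among the compounds shown, and "the series" means these compounds.

Measured so far in a functional assay on HepG2 cells (Homo sapiens) for inhibition, read by MTT assay; a lower number here means a stronger inhibitor, a higher number a weaker inhibitor:
Compound 1 `COc1cc2ncnc(Nc3ccc(NC(=O)c4cccc(C)c4)cc3)c2cc1OC`: 7500 nM
Compound 2 `COc1cc2ncnc(Nc3ccc(NC(=O)c4ccc(Cl)cc4)cc3)c2cc1OC`: 28000 nM

Compound 2 holds the higher of the two numbers, so it is the weaker inhibitor of the pair in this assay. Among the measured compounds shown here, its only neighbour is compound 1, and the gap, a 3.7-fold higher number from compound 1 to compound 2 (0.57 log units; beyond the scatter), is modest but beyond the scatter.

The next compound is compound 3 `COc1cc2ncnc(Nc3ccc(NC(=O)c4ccccc4I)cc3)c2cc1OC`, with this change: 2-iodophenyl in place of 4-chlorophenyl on a carbonyl carbon. In short, 2-iodophenyl stands in place of 4-chlorophenyl on a carbonyl carbon. For the measured compounds named here, only one measured step bears on this, a 3.7-fold higher number from compound 1 to compound 2 (0.57 log units; beyond the scatter), which changes the aryl group on the same carbonyl carbon. It shows that this group can move the number by a modest amount. Going by the values given here, no measured compound carries iodine or a group named as 2-substituted, so the direction rests on thin ground. With compound 2 at the high end of the two values, a modest move toward a lower number is expected, and no change beyond the scatter remains possible.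

The estimated step is a 1.9-fold lower number from compound 2 to compound 3 (0.27 log units; within the scatter). For compound 3 the estimated value is 15000 nM, with an expected range of 5000 nM to 50000 nM.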

Compound 3, half-maximal inhibitory concentration: 33000 nM
The estimate for compound 3 lay 2.2-fold (0.34 log units) below the measured number; the range from low to high includes it.
By their numbers in this assay, from the lowest: compound 1; then compounds 2 and 3 (each within the scatter of the next).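

In this assay, putting 2-iodophenyl in place of 4-chlorophenyl on the carbonyl carbon gives a 1.2-fold higher number from compound 2 to compound 3 (0.07 log units; within the scatter), so these two halogen-bearing aryl groups cannot be told apart at this position, even though both the halogen and its place on the ring differ. Against the 3-methylphenyl group of compound 1, which gives 7500 nM, the same new group gives a 4.4-fold higher number from compound 1 to compound 3 (0.64 log units; beyond the scatter), a modest step beyond the scatter and close in size to the step already seen for 4-chlorophenyl. Among these three compounds, then, compound 1 stands apart from the two halogen-bearing compounds, with none of the three going against that reading, and no measurement at hand explains the separation.

Still open, as far as these compounds go, is whether the gap to compound 1 follows the methyl group or its place on the ring, as the aryl groups differ in both at once. Also open, from the compounds shown here alone, is how the number responds to an amine or a carboxylic acid on this ring, or to a longer chain in place of the aryl group on the carbonyl carbon.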